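Shifting a chlorine on a weak receptor antagonist

The source may report more compounds than this note shows. Statements on the series, on what has been measured and on what is new or still open speak of the compounds shown alone.

Of the compounds shown here, two from this series have been tested, and both sit at the weak end. Compound 1, with the structure `CCOc1ccc(OCCC(O)CN(C)Cc2c(C)nn(Cc3ccccc3Cl)c2C)cc1`, was examined in an assay on cells for antagonist activity at Toll-like receptor 4 (Homo sapiens), with a stated time of 24 h (on this read-out lower numbers stand for stronger inhibition and higher numbers for weaker inhibition), and in that test compound 1 gave "not active" (no number reported), so no single number stands for it. Compound 2, with the structure `Cc1nn(Cc2ccccc2Cl)c(C)c1CN(C)CC(O)CCOc1ccc(F)cc1`, is built differently at the far end of the chain; in this assay compound 2 gives 55400 nM, a very weak result. Among the compounds with values here, the two compounds share the same core, and the only thing the two values show is that neither reaches useful strength.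

The next compound to be tested is compound 3, with the structure `CCOc1ccc(OCCC(O)CN(C)Cc2c(C)nn(Cc3ccc(Cl)cc3)c2C)cc1`. It keeps every atom of compound 1 but rearranges one part: 4-chlorophenyl in place of 2-chlorophenyl on a saturated chain carbon bound to an aromatic nitrogen. Within the data shown here, nothing among the tested compounds shows what this change does, so no step of size beyond the usual scatter is expected in this assay in either direction. Compound 3 is therefore expected to stay very weak, with an estimated value of 60000 nM in a range from 20000 nM to 200000 nM, and it may well be reported as not active again.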

Compound 3, half-maximal inhibitory concentration: 25900 nM
Beside the measured number, compound 3's estimate is 2.3-fold (0.36 log units) above it; measured number inside the range.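

Within the data shown here, compound 1 has no number in this assay, only the result "not active", so no step from compound 1 to compound 3 can be read, and compound 2 differs from compound 3 in more than one place. The compounds shown leave open what 4-chlorophenyl in place of 2-chlorophenyl does to strength. No supporting data bear on the result for compound 3.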